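Amide substituent variation in a vitamin D receptor series

A few compounds are considered here, and "the series" means these few. Any claim that something is new, unique, unknown or untested is made for them only; others in the source may bear on it.

Measured so far:
Compound 1 `CCn1c(C(=O)NCCCN(C)C)ccc1C(CC)(CC)c1ccc(OCC(O)C(C)(C)C)c(C)c1` gives 197 nM in an assay on isolated protein for binding affinity to vitamin D3 receptor (Homo sapiens), with a stated time of 4 h; a lower number here means a stronger inhibitor, a higher number a weaker inhibitor.
Compound 2 `CCn1c(C(=O)N(CCC#N)CCC#N)ccc1C(CC)(CC)c1ccc(OCC(O)C(C)(C)C)c(C)c1` gives a limit of > 10000 nM in this assay.

Compound 1 holds the only number shown in this assay. The value of compound 2 is a limit of the assay. Compound 3 `CCOc1ccc(NC(=O)c2ccc(C(CC)(CC)c3ccc(OCC(O)C(C)(C)C)c(C)c3)n2CC)cc1` differs from compound 1 by 4-ethoxyphenyl in place of 3-(dimethylamino)propyl on an amide-type nitrogen. Within the data shown here, one measured step bears on this: an at least 50-fold higher number from compound 1 to compound 2 (1.70 log units; beyond the scatter), with the limit of > 10000 nM in this assay, at which 1 of the 2 values shown sits, applying. That step removes the amide hydrogen and brings in nitriles, while compound 3 keeps the amide hydrogen, so it bears only loosely. A moderate weakening is expected, a 3.0-fold higher number from compound 1 to compound 3 (0.48 log units; beyond the scatter). Compound 3 is estimated at 600 nM, range 100 nM to 6000 nM.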

Compound 3, half-maximal inhibitory concentration: 9250 nM
Beside the measured number, compound 3's estimate is 15-fold (1.19 log units) below it, outside the stated range (above it).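

In this assay, keeping the amide hydrogen does not preserve binding: 4-ethoxyphenyl in place of 3-(dimethylamino)propyl on the amide-type nitrogen gives a 47-fold higher number from compound 1 to compound 3 (1.67 log units; beyond the scatter). The amide hydrogen alone therefore does not secure the number seen for compound 1, and both other substituents shown sit far from it. The remaining step is an at least 1.0-fold lower number from compound 2 to compound 3 (0.03 log units; that floor lies within the scatter), and it sets no order. Compound 2 carries a limit of the assay and not a number: the limit of > 10000 nM in this assay, at which 1 of the 3 values shown sits.

As far as these compounds go, whether the terminal dimethylamino group or the propyl chain matters more stays open. A plain propyl chain, a primary amine on that chain or a carboxylic acid at its end would separate the two.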